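A few compounds are considered here, and "the series" means these few. Any claim that something is new, unique, unknown or untested is made for them only; others in the source may bear on it.

Measured compounds:
compound 1 `C#Cc1cccc(Nc2ncnc3cc(OC)c(OCCCCC(=O)Nc4ccc(S(N)(=O)=O)cc4)cc23)c1`, 17700 nM
compound 2 `COc1cc2ncnc(Nc3ccc(F)cc3)c2cc1OCCCCC(=O)Nc1ccc(S(N)(=O)=O)cc1`, 18600 nM
compound 3 `COc1ccc(Nc2ncnc3cc(OC)c(OCCCCC(=O)Nc4ccc(S(N)(=O)=O)cc4)cc23)cc1OC`, 35400 nM

Three compounds sharing one core were tested in a functional assay on A-431 cells (Homo sapiens) for antiproliferative activity, read by MTT assay, with a stated time of 72 h (on this read-out higher numbers stand for weaker inhibition and lower numbers for stronger inhibition), and they differ only in the aryl group carried on the nitrogen attached to the core. Compound 3, with a 3,4-dimethoxyphenyl there, cannot be set apart from the other two: the step of a 2.0-fold higher number from compound 1 to compound 3 (0.30 log units; within the scatter) and the step of a 1.9-fold higher number from compound 2 to compound 3 (0.28 log units; within the scatter) both stay inside the scatter, as does the step of a 1.1-fold higher number from compound 1 to compound 2 (0.02 log units; within the scatter) between the other pair. On the numbers shown, the three aryl groups therefore behave alike in this assay.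

Compound 4 `COc1cc2ncnc(Nc3cccc(Cl)c3F)c2cc1OCCCCC(=O)Nc1ccc(S(N)(=O)=O)cc1` is the next member, not yet measured. It carries 3-chloro-2-fluorophenyl in place of 3,4-dimethoxyphenyl on a nitrogen on an aromatic ring. All three measured steps bear on this change, since each swaps one aryl group on that nitrogen for another, and none of them moved the number beyond the scatter. No step beyond the scatter in this assay is expected for compound 4, so the step of a 1.6-fold lower number from compound 3 to compound 4 (0.21 log units; within the scatter) is estimated to stay small. Compound 4 is accordingly expected to give about 22000 nM in this assay, with a range from 9000 nM to 55000 nM.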

Compound 4, half-maximal inhibitory concentration: 5560 nM
The estimate for compound 4 lay 4.0-fold (0.60 log units) above the measured number, and the stated range ends above it.
By their numbers in this assay, from the lowest: compound 4; then compounds 1, 2 and 3 (each within the scatter of the next).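

In this assay the aryl group on the nitrogen attached to the shared core is no longer without effect: 3-chloro-2-fluorophenyl gives a 6.4-fold lower number from compound 3 to compound 4 (0.80 log units; beyond the scatter) and a 3.3-fold lower number from compound 2 to compound 4 (0.52 log units; beyond the scatter) and also a 3.2-fold lower number from compound 1 to compound 4 (0.50 log units; beyond the scatter) against the three other aryl groups. All three steps run the same way and lie beyond the scatter, so this position can move the number even though the three earlier aryl groups could not be told apart. Nothing measured here accounts for the difference.

The compounds shown leave open whether the chlorine alone or its combination with the fluorine goes with this step, a question that a 3-chlorophenyl or a 2-fluorophenyl group on the same nitrogen would address. They also leave open whether the step would persist with a longer chain on the oxygen of the core or with a carboxylic acid in place of the sulfonamide.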